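A few compounds are considered here, and "the series" means these few. Any claim that something is new, unique, unknown or untested is made for them only; others in the source may bear on it.

Of the compounds shown here, three built on the same core have been tested. Compound 1 `COc1ccc(-n2cc(-c3ccc(Cl)cc3)[nH]c2=S)cc1Cl` gives 20000 nM in a functional assay on SF-539 cells (Homo sapiens) for antiproliferative activity; a lower number here means a stronger inhibitor of growth, a higher number a weaker inhibitor of growth. Compound 2 `COc1cc(-n2cc(-c3ccc(Cl)cc3)[nH]c2=O)cc(OC)c1OC` gives 25100 nM in this assay, and compound 3 `COc1ccc(-n2cc(-c3ccc(OC)c(OC)c3)[nH]c2=S)cc1Cl` gives 39800 nM. Compound 2 holds the second highest of the three numbers, yet all three lie within the scatter of one another, so no ranking among them can be drawn. Compound 4 `COc1cc(-n2cc(-c3ccccc3)[nH]c2=O)cc(OC)c1OC` has not yet been measured in this assay. It differs from compound 2 by hydrogen in place of chloro on an aromatic carbon. Among the compounds with values here, no pair of measured compounds shows this change, so its effect cannot be read from what is known. The expected step in this assay is a 1.4-fold higher number from compound 2 to compound 4 (0.14 log units; within the scatter), small and, if anything, toward a higher number. For compound 4 the estimate is 35000 nM, with a range from 12000 nM to 100000 nM.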

Compound 4, concentration for 50% growth inhibition: 20000 nM
Estimate against measurement, compound 4: 1.8-fold (0.24 log units) above, and the stated range covers the measured number.
By their numbers in this assay, from the lowest: compounds 1, 4, 2 and 3 (each within the scatter of the next).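

The change from 4-chlorophenyl to phenyl gives a 1.3-fold lower number from compound 2 to compound 4 (0.10 log units; within the scatter) in this assay, the first step read at this position. In this pair, the chloro at this place, para to a large group, can be replaced by hydrogen without a difference that rises above the scatter. Nothing available bears on the reason for this.

Going by these compounds, whether an amine or a carboxylic acid at this position would give a step beyond the scatter remains open. On these data alone, it is also open whether the same change would read alike starting from compound 1.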